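A few compounds are considered here, and "the series" means these few. Any claim that something is new, unique, unknown or untested is made for them only; others in the source may bear on it.

For the measured compounds named here, the two compounds measured so far share one core. Compound 1 `C[Si](C)(C)CCOCn1c(CC(O)(COCc2ccccc2)COCc2ccccc2)cc(=O)[nH]c1=O` carries a long chain on the aromatic nitrogen, while compound 2 `O=c1cc(CC(O)COCc2ccccc2)[nH]c(=O)[nH]1` has a hydrogen there. In a functional assay on MIA PaCa-2 cells (Homo sapiens) for antiproliferative activity, read by MTT assay, with a stated time of 72 h (on this read-out higher numbers stand for weaker inhibition and lower numbers for stronger inhibition), compound 1 gives > 100000 nM, which is a limit of the assay and not a number. In this assay compound 2 gives > 100000 nM, again a limit rather than a number. Compound 2 thus stands at the edge of what the assay can report, and the same holds for every value shown (the limit of > 100000 nM in this assay, at which 2 of the 2 values shown sit). Compound 3 `C[Si](C)(C)CCOCn1c(CC(O)COCc2ccccc2)cc(=O)[nH]c1=O` has not been measured. It differs from compound 2 by a group of 8 heavy atoms (6 carbon, 1 oxygen, 1 silicon; no ring) in place of a hydrogen atom, on an aromatic nitrogen. Going by the values given here, with both known compounds sitting at the limit, no measured step is available, and no shift beyond the scatter in either direction is expected. Compound 3 is expected to give 150000 nM, within a range from 50000 nM to 500000 nM. The expected step is a step that the limit leaves unreadable from compound 2 to compound 3.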

Compound 3, half-maximal inhibitory concentration: > 100000 nM
Compound 3 gave a limit, no number; the forecaster's own chance of this, stated with the estimate: 85%; the middle value does not contradict the limit.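

For the compounds shown here, with compound 3 also at a limit and not a number, no step linking it to compound 1 or compound 2 can be read in this assay: the limit of > 100000 nM in this assay, at which 3 of the 3 values shown sit. The compounds shown leave open whether the group on the aromatic nitrogen or the (benzyloxy)methyl group changes antiproliferative activity at all.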